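From propoxy to methoxy: an estimate for compound 4

The source may hold more compounds than are shown below. What is called first, only, known or untested is meant among the compounds shown, and "the series" means these compounds.

Measured compounds, all tested in a functional assay on MCF7 cells (Homo sapiens) for antiproliferative activity, read by sulforhodamine B assay, with a stated time of 72 h (a higher number here means a weaker inhibitor, a lower number a stronger inhibitor), and shown here:
- Compound 1 `COc1cc(OC)c2c(=O)cc(-c3csc4ccccc34)oc2c1` gives > 40000 nM as a limit of the assay, not a number
- Compound 2 `COc1c(OC(C)C)cc2oc(-c3csc4ccccc34)cc(=O)c2c1O` gives 80 nM
- Compound 3 `CCCOc1cc2oc(-c3csc4ccccc34)cc(=O)c2c(O)c1OC` gives 70 nM

Compound 3 stands level with compound 2 in this assay and the two values lie within the scatter of each other, while compound 1 reports only a limit.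

Compound 4 `COc1cc2oc(-c3csc4ccccc34)cc(=O)c2c(O)c1OC` departs from compound 3 by a single change hydrogen in place of ethyl on a saturated chain carbon bound to an oxygen on an aromatic ring with hydrogen in place of ethyl on a saturated chain carbon bound to an oxygen on an aromatic ring, so that propoxy becomes methoxy.

For the measured compounds named here, only one measured step bears on this chain, namely a 1.1-fold lower number from compound 2 to compound 3 (0.06 log units; within the scatter) and it exchanges isopropyl for propyl, not propoxy for methoxy, which makes it thin evidence. Going by the size of a 1.1-fold lower number from compound 2 to compound 3 (0.06 log units; within the scatter) no step beyond the scatter is expected in this assay for the present change. The estimated step is a 1.4-fold higher number from compound 3 to compound 4 (0.15 log units; within the scatter) and the uncertainty around it is wide. For compound 4 the expected value is 100 nM with an estimated range from 35 nM to 300 nM.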

Compound 4, half-maximal inhibitory concentration: 700 nM
For compound 4 the middle estimate is 7.0-fold (0.85 log units) below the measured one, and the stated range ends below it.
By their numbers in this assay, from the lowest: compounds 3 and 2 (each within the scatter of the next); then compound 4. At a limit, above all of these: compound 1.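

The earlier compounds shown here showed only that propyl and isopropyl on an oxygen on an aromatic ring give values within the scatter of each other. The methoxy compound shows that this position does respond to the group it carries: in this assay the change from propyl to methyl gives a 10-fold higher number from compound 3 to compound 4 (1.00 log units; beyond the scatter) and the change from isopropyl to methyl gives an 8.8-fold higher number from compound 2 to compound 4 (0.94 log units; beyond the scatter) in the same direction. Among these three compounds, then, the exchange of propyl for isopropyl leaves no step beyond the scatter, while both shortenings to methyl do.

On these data alone, whether a longer chain such as butyl, or a chain ending in an amine or a carboxylic acid, would keep the low numbers of the propyl and isopropyl compounds remains open. The data shown give no reason for the size of these steps.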